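Aryl swap on a shared core: cytotoxicity working notes

The source may report more compounds than this note shows. Statements on the series, on what has been measured and on what is new or still open speak of the compounds shown alone.

The series keeps one core and varies only the aryl group on the double-bonded chain. For compound 1 `CNC(=O)c1cc(Oc2ccc(C(=O)/C=C/c3cccc([N+](=O)[O-])c3)cc2)ccn1` the entry in a functional assay on A549 cells (Homo sapiens) for cytotoxicity, read by MTT assay, with a stated time of 72 h (a lower number here means a stronger inhibitor, a higher number a weaker inhibitor), reads "not determined" (no result reported). Compound 2 `CNC(=O)c1cc(Oc2ccc(C(=O)/C=C/c3cc(OC)c(OC)c(OC)c3)cc2)ccn1` gives 9500 nM in this assay. Compound 3 `CNC(=O)c1cc(Oc2ccc(C(=O)/C=C/c3ccc(F)cc3)cc2)ccn1` gives 18600 nM in this assay; this is the higher of the two numbers available, yet the gap to compound 2 lies within the scatter, so no order between compound 2 and compound 3 can be read from these values. Compound 4 `CNC(=O)c1cc(Oc2ccc(C(=O)/C=C/c3cccc(Cl)c3Cl)cc2)ccn1` is not yet measured. It differs from compound 3 by 2,3-dichlorophenyl in place of 4-fluorophenyl on a double-bonded chain carbon bound to a double-bonded chain carbon. Among the compounds with values here, no measured pair in this set isolates such a change, so the size of the step cannot be taken from data. The two measured numbers sit close together despite rather different aryl groups, which hints that the aryl group moves the read-out only modestly in this set. Compound 1 has no number. It cannot be placed in that picture. For compound 4 a step no larger than the scatter is expected in this assay, if anything toward a lower number. Compound 4 is estimated at 12000 nM, with a range from 5000 nM to 30000 nM. The expected step is a 1.6-fold lower number from compound 3 to compound 4 (0.19 log units; within the scatter).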

Compound 4, half-maximal inhibitory concentration: > 50000 nM
Compound 4: no number, only a limit; the forecaster's own chance of this, stated with the estimate: 10%; middle value at least 4.1-fold (0.61 log units) away from the limit.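

In this assay compound 4 carries a limit and not a number: the limit of > 50000 nM in this assay, at which 1 of the 4 values shown sits. Even so, the step can be read in one direction: 2,3-dichlorophenyl in place of 4-fluorophenyl gives an at least 2.6-fold higher number from compound 3 to compound 4 (0.42 log units; beyond the scatter), so the aryl group on a double-bonded chain carbon bound to a double-bonded chain carbon can move the read-out beyond the scatter, which compound 2 and compound 3 alone did not show. The two groups have the same ring and the same counts of hydrogen-bond donors, hydrogen-bond acceptors and net charge, so these counts do not separate compound 3 from compound 4, and the change that is visible here is two chlorine in place of one fluorine, with no cause for the step given by the data.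

Within the data shown here, how far compound 4 lies past its limit cannot be read, and no step to compound 1 can be read either, as it has no number. The compounds shown leave open whether an aryl group with a single chlorine, or one carrying an amine or a carboxylic acid, would stay close to compound 3 or follow compound 4.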